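Selenium-bearing bisacyl compounds and the limit of a cytotoxicity test

The source may report more compounds than this note shows. Statements on the series, on what has been measured and on what is new or still open speak of the compounds shown alone.

The series rests on three measured compounds that share one core, with the selenium carrying a methyl. Compound 1 is `C[Se]/C(=N\C(=O)c1ccco1)NC(=O)c1ccco1`, and in a functional assay on PC-3 cells (Homo sapiens) for cytotoxicity, read by MTT assay, with a stated time of 72 h (on this read-out higher numbers stand for lower toxicity in this test and lower numbers for higher toxicity in this test), compound 1 gives only a limit of the assay, > 100000 nM. Compound 2 is `C[Se]/C(=N\C(=O)c1cccs1)NC(=O)c1cccs1`, and in this assay compound 2 likewise reaches only the limit, > 100000 nM. Compound 3 is `C[Se]/C(=N\C(=O)c1ccno1)NC(=O)c1ccno1`, and compound 3 again shows only the limit, > 100000 nM. All three therefore stand at the same place, which is the limit of > 100000 nM in this assay, at which 3 of the 3 values shown sit, so nothing separates them on the numbers shown.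

Compound 4 is `O=C(/N=C(/NC(=O)c1ccco1)[Se]Cc1ccccc1)c1ccco1`. It differs from compound 1 by phenyl in place of hydrogen on a saturated chain carbon bound to a selenium atom. Among the measured compounds shown here, no measured step of this kind is available, so the expected size of the step from compound 1 to compound 4 is small, and compound 4 is estimated to sit at a number no higher from compound 1 to compound 4 (the limit leaves the size open). Compound 4 is therefore expected to give about 100000 nM, within 30000 nM to 300000 nM, most likely again as a limit.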

Compound 4, concentration lethal to 50% of the cells: 84800 nM
Compound 4: middle estimate off by 1.2-fold (0.07 log units), on the high side, within the range that was stated.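

In this assay, among the compounds shown here, the change from methyl to benzyl at this place gives the first value that is a number rather than a limit, with an at least 1.1-fold lower number from compound 1 to compound 4 (0.07 log units; that floor lies within the scatter). As far as these compounds go, compound 1 gives only a limit, so this step is a floor and its true size stays open. The phenyl on the saturated chain carbon bound to the selenium atom therefore permits a measurable reading, but the series still sits mostly at the limit: the limit of > 100000 nM in this assay, at which 3 of the 4 values shown sit.

The compounds shown leave open whether the phenyl itself matters or whether a longer chain without a ring, such as a propyl chain, would give a similar reading. They also leave open whether an amine or a carboxylic acid on that phenyl would shift the value, and whether benzyl would act alike on the cores of compound 2 and compound 3.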